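Replacing the Chloro of Compound 1 with Hydrogen

The compounds below may be only part of what the source reports. "The series", "measured", "known", "first", "only" and "open" are said of these compounds alone.

In an ADME assay on HEK293 cells (Homo sapiens) for cytotoxicity, read by reporter gene assay and resazurin assay, with a stated time of 48 h (a higher number here means that more compound is tolerated, a lower number that less compound is tolerated), compound 1 `O=C(Nc1cccc(Cl)c1)c1cc(Br)cc(Br)c1O` gives 18000 nM, the lower of the two actual numbers in this small set. The nearest value belongs to compound 2 `O=C(Nc1cccc(Cl)c1)c1cc(Br)cc(Br)c1`, which gives 53000 nM. Compound 3 `COc1c(Br)cc(Br)cc1C(=O)Nc1ccc(Sc2nc3ccccc3s2)c(Cl)c1` is reported only as a limit, > 100000 nM.

Compound 4 `O=C(Nc1ccccc1)c1cc(Br)cc(Br)c1O` has hydrogen in place of chloro on an aromatic carbon, and its difference from the parent is hydrogen in place of chloro on an aromatic carbon. Among the measured compounds shown here, no measured step covers this change. The closest guide is the swap of hydroxy for hydrogen, which gave a 2.9-fold higher number from compound 1 to compound 2 (0.47 log units; beyond the scatter). That step changes a different group, so it offers only a rough indication of size and direction. For the measured compounds named here, a small move toward a higher number in this assay is therefore expected, no larger than that step. The expected change is a 1.7-fold higher number from compound 1 to compound 4 (0.22 log units; within the scatter). For compound 4 the estimate is 30000 nM, with an expected range from 12000 nM to 75000 nM.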

Compound 4, half-maximal cytotoxic concentration: 34000 nM
Compound 4: middle estimate off by 1.1-fold (0.05 log units), on the low side; measured number inside the range.
By their numbers in this assay, from the lowest: compounds 1, 4 and 2 (each within the scatter of the next, the first and the last beyond it). At a limit, above all of these: compound 3.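

With hydrogen in place of chloro on an aromatic carbon, meta to a large group, this assay gives a 1.9-fold higher number from compound 1 to compound 4 (0.28 log units; within the scatter), so this swap does not separate the two compounds beyond the usual scatter. The only earlier step, at the hydroxy group, gave a 2.9-fold higher number from compound 1 to compound 2 (0.47 log units; beyond the scatter), which lies beyond the scatter, so among these compounds the hydroxy position registers in this assay while the chloro position does not. Nothing measured here bears on why the chloro can be lost with so little consequence.

Only chloro and hydrogen are shown at this place, so it remains open whether an amine, a carboxylic acid or a longer chain there would give a clearer step. On these data alone, it also remains open whether the small size of this step would hold if the hydroxy group were absent from the shared core.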